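Working notes on a step in the permeability series

This account rests on a few compounds, and the source may have more. Where it says the series, first, only, none or still open, it means among the compounds named here.

Values in an ADME assay on MDCK-II cells (Canis lupus familiaris) for permeability (on this read-out lower numbers stand for lower permeability and higher numbers for higher permeability), for the measured compounds:
Compound 1 `CC(C)Oc1cc(Oc2ccc(S(C)(=O)=O)cc2)cc(-c2cncc(=O)[nH]2)c1` gives 94 10^-6 cm/s
Compound 2 `Cc1cnc(-c2cc(Oc3ccc(S(C)(=O)=O)cc3)cc(OC(C)C)c2)[nH]c1=O` gives 17 10^-6 cm/s
Compound 3 `CCc1cnc(-c2cc(Oc3ccc(S(C)(=O)=O)cc3)cc(OC(C)C)c2)[nH]c1=O` gives 4 10^-6 cm/s

Compound 1 stands highest of the three numbers in this assay and both other compounds lie beyond the scatter from it. Compound 4 `CC(C)Oc1cc(Oc2ccc(S(C)(=O)=O)cc2)cc(-c2ncc(Cl)c(=O)[nH]2)c1` is still unmeasured. Its difference from compound 1 is a group of 8 heavy atoms (4 carbon, 2 nitrogen, 1 oxygen, 1 chlorine; one six-membered aromatic ring with 2 hetero atoms) in place of a group of 7 heavy atoms (4 carbon, 2 nitrogen, 1 oxygen; one six-membered aromatic ring with 2 hetero atoms), on an aromatic carbon and the place is on an aromatic carbon of a six-membered aromatic ring of carbon only, meta to a large group and meta to an isopropoxy group.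

Two measured steps replace the same group at this place. For the measured compounds named here, they are a 5.5-fold lower number from compound 1 to compound 2 (0.74 log units; beyond the scatter) and a 24-fold lower number from compound 1 to compound 3 (1.37 log units; beyond the scatter) and both go down, with no measured compound against that direction. The remaining step of a 4.3-fold lower number from compound 2 to compound 3 (0.63 log units; beyond the scatter) concerns a change on a saturated chain carbon and bears on compound 4 only loosely. Going by the values given here, no measured compound carries chlorine, so the size rests on the first of these steps as the nearest guide, with wide uncertainty.

A lower number is expected, with the estimated step of a 6.3-fold lower number from compound 1 to compound 4 (0.80 log units; beyond the scatter) beyond the scatter. For compound 4 the expected value in this assay is 15 10^-6 cm/s within an estimated range from 4 10^-6 cm/s to 50 10^-6 cm/s before any measurement.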

Compound 4, apparent permeability: 8.3 10^-6 cm/s
Beside the measured number, compound 4's estimate is 1.8-fold (0.26 log units) above it; measured number inside the range.
By their numbers in this assay, from the lowest: compound 3; then compound 4; then compound 2; then compound 1.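

At this place the chloro-bearing group follows the same direction as the two alkyl-bearing groups, with an 11-fold lower number from compound 1 to compound 4 (1.05 log units; beyond the scatter) in this assay, so all three replacements of the group in compound 1 go down and none goes against them. Among the three substituted groups, chloro falls in the interval set by methyl and ethyl: the series shows a 2.0-fold lower number from compound 2 to compound 4 (0.31 log units; beyond the scatter) and a 2.1-fold higher number from compound 3 to compound 4 (0.32 log units; beyond the scatter), both modest but beyond the scatter. The groups in compound 2 and compound 4 hold the same number of heavy atoms yet differ beyond the scatter, so heavy-atom count alone does not order these compounds.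

The ring hetero atoms in compound 1 are arranged differently from those in compound 2, compound 3 and compound 4, and the compounds shown include no unsubstituted form of the latter ring, so the share of the drop belonging to chloro itself remains open. From the compounds shown here alone, it also remains open whether an amine, a methoxy group or a nitrile on the same ring carbon would follow the downward direction.

No supporting data bear on what lies behind these differences.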